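The source may report more compounds than this note shows. Statements on the series, on what has been measured and on what is new or still open speak of the compounds shown alone.

Compound 1 `CCCCNc1nc(N)nnc1OCc1ccccc1OC` gives 640 nM in an assay on isolated protein for agonist activity at Toll-like receptor 8 (Homo sapiens); a lower number here means that less compound is needed, a higher number that more compound is needed for the effect.
Compound 2 `CCCCNc1nc(N)nnc1OC(C)C` gives 460 nM.
Compound 3 `CCCCNc1nc(N)nnc1OCc1ccccc1F` gives 560 nM.

The three compounds share one core and differ only in the group carried on the oxygen of that core. Compound 3 sits second highest of the three numbers, but every gap is small: the change from compound 1 to compound 3 is a 1.1-fold lower number from compound 1 to compound 3 (0.06 log units; within the scatter), and compound 2 lies within the scatter of compound 3 as well. On the numbers shown, the three groups on the oxygen are indistinguishable in this assay.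

Compound 4 `CCCCNc1nc(N)nnc1OCc1ccccn1` is the next variant. It differs from compound 3 by pyridin-2-yl in place of 2-fluorophenyl on a saturated chain carbon bound to an oxygen on an aromatic ring. Among the measured compounds shown here, the only measured step that bears on a change at this part of the molecule is the one from compound 1 to compound 3, which was within the scatter, and the wider comparison of compound 2 with compounds 1 and 3 points the same way: three quite different groups on the oxygen gave numbers that could not be told apart. Compound 4 is therefore expected to sit close to compound 3, with a step of a 1.0-fold lower number from compound 3 to compound 4 (0.01 log units; within the scatter) that is not expected to exceed the scatter. The estimate for compound 4 is 550 nM, within 250 nM to 1200 nM.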

Compound 4, half-maximal effective concentration: 330 nM
The estimate for compound 4 lay 1.7-fold (0.22 log units) above the measured number; the measured number falls inside the stated range.
By their numbers in this assay, from the lowest: compounds 4, 2, 3 and 1 (each within the scatter of the next).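

The step from the 2-fluorophenyl group to the pyridin-2-yl group in this assay is a 1.7-fold lower number from compound 3 to compound 4 (0.23 log units; within the scatter), so a ring with one hetero atom and one hydrogen-bond acceptor cannot be told apart from a ring of carbon only at this place. The earlier step at this part of the molecule, a 1.1-fold lower number from compound 1 to compound 3 (0.06 log units; within the scatter), changed only a substituent on an aromatic carbon, whereas this one changes the six-membered aromatic ring itself, and the result again stays within the scatter. The four compounds thus show no measurable preference among these groups on the oxygen of the shared core, and nothing available explains the small difference seen for compound 4.

Going by these compounds, it remains open whether a group of another kind on that oxygen, such as a primary amine, a carboxylic acid or a longer chain on the saturated carbon, would move the number beyond the scatter. Also open, on these data alone, are whether pyridin-3-yl or pyridin-4-yl would behave like pyridin-2-yl, and how far the number depends on the butylamino group, which all four compounds share.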